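Aryl variation at the saturated ring carbon: cytotoxicity notes

A few compounds are considered here, and "the series" means these few. Any claim that something is new, unique, unknown or untested is made for them only; others in the source may bear on it.

Measured so far:
- compound 1 `O=C1CSC(c2cccc(Cl)c2)N1CCN1CCCCC1`, 15%
- compound 2 `O=C1CSC(c2ccc(O)cc2)N1CCN1CCCCC1`, 10%
- compound 3 `O=C1CSC(c2ccc(F)cc2)N1CCN1CCCCC1`, 11%

All three were read in an ADME assay on Vero cells (Chlorocebus sabaeus) for cytotoxicity, read by neutral red uptake, tested at 3150 ug/mL; on this read-out lower numbers stand for a stronger effect and higher numbers for a weaker effect at the one concentration tested. Compound 1 holds the top number of the three, but neither gap reaches beyond the scatter: a number 5 percentage points lower from compound 1 to compound 2 (within the scatter) and a number 4 percentage points lower from compound 1 to compound 3 (within the scatter). The pair of compound 2 and compound 3 is also flat, a number 1 percentage points higher from compound 2 to compound 3 (within the scatter). The aryl group on the saturated ring carbon has thus been varied three ways without a step that stands out.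

Compound 4 `COc1cccc(C2SCC(=O)N2CCN2CCCCC2)c1` is next. Relative to compound 1 the change is methoxy in place of chloro on an aromatic carbon. Within the data shown here, no measured step swaps one substituent for another on the same aromatic ring of compound 1; the only steps that bear on it are the aryl replacements from compound 1, each within the scatter. Compound 4 is therefore expected to show a number 1 percentage points lower from compound 1 to compound 4 (within the scatter), that is, no step beyond the scatter. The estimate for compound 4 is 14%, with a range from 5% to 28%.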

Compound 4, a percentage reported as activity, at one concentration (the size of the read-out at that concentration, not a potency): 6%
Estimate against measurement, compound 4: 8 percentage points above, within the range that was stated.
By their numbers in this assay, from the lowest: compounds 4, 2, 3 and 1 (each within the scatter of the next).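

In this assay, among these compounds, the step of a number 9 percentage points lower from compound 1 to compound 4 (within the scatter) is the first read that exchanges one substituent for another on the same aromatic ring of compound 1, with methoxy in place of chloro. The earlier steps shown here from compound 1 replaced the whole aryl group, whereas this one keeps the ring and the place, meta to a large group, and still gives no step beyond the scatter. Nothing at hand explains the numbers of this series or bears on this exchange.

Open, going by these compounds, is whether an amine or a carboxylic acid on this aromatic carbon would give a step beyond the scatter. On these data alone, a longer chain in place of the methoxy, such as ethoxy or butoxy, remains equally open.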